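A few compounds are considered here, and "the series" means these few. Any claim that something is new, unique, unknown or untested is made for them only; others in the source may bear on it.

Working notes on the amine substituent of the series. In a functional assay on NCI-H460 cells (Homo sapiens) for inhibition, read by sulforhodamine B assay, with a stated time of 72 h (on this read-out higher numbers stand for weaker inhibition and lower numbers for stronger inhibition), compound 1 `CCNC(=O)c1nnn(-c2cc(C(C)C)c(O)cc2O)c1-c1ccc(CN2CCC[C@@H](O)C2)cc1` gives 52 nM, compound 2 `CCNC(=O)c1nnn(-c2cc(C(C)C)c(O)cc2O)c1-c1ccc(CN2CCNCC2)cc1` gives 250 nM and compound 3 `CCNC(=O)c1nnn(-c2cc(C(C)C)c(O)cc2O)c1-c1ccc(CNC2CCCCC2)cc1` gives 15 nM, the lowest of the three numbers. Compound 4 `CCNC(=O)c1nnn(-c2cc(C(C)C)c(O)cc2O)c1-c1ccc(CNCCCN(CC)CC)cc1` has 3-(diethylamino)propyl in place of cyclohexyl on an amine nitrogen.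

For the measured compounds named here, two measured steps bear on this change, since both end at the cyclohexylamino group now being replaced: a 3.5-fold lower number from compound 1 to compound 3 (0.54 log units; beyond the scatter), a modest step, and a 17-fold lower number from compound 2 to compound 3 (1.22 log units; beyond the scatter), a large one. In both, the number falls on reaching cyclohexylamino, so leaving that group is expected to raise it. Going by the values given here, no measured compound carries an open chain at this place, which leaves the size uncertain. The entering group holds a nitrogen, as the piperazin-1-yl of compound 2 does at 250 nM, and that value marks the likely upper region. A modest rise is expected in this assay, an estimated 3.3-fold higher number from compound 3 to compound 4 (0.52 log units; beyond the scatter). For compound 4 the expected value is 50 nM, with an estimated range of 15 nM to 170 nM.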

Compound 4, half-maximal inhibitory concentration: 412 nM
Estimate against measurement, compound 4: 8.2-fold (0.92 log units) below; measured number outside the range, above it.
By their numbers in this assay, from the lowest: compound 3; then compound 1; then compounds 2 and 4 (each within the scatter of the next).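

In this assay, replacing cyclohexyl with 3-(diethylamino)propyl on the amine nitrogen proves a large loss (as a 27-fold higher number from compound 3 to compound 4 (1.44 log units; beyond the scatter) shows), and the comparison with the hydroxylated ring is also unfavourable (a 7.9-fold higher number from compound 1 to compound 4 (0.90 log units; beyond the scatter)). The comparison with the piperazine (a 1.6-fold higher number from compound 2 to compound 4 (0.22 log units; within the scatter)) lies within the scatter, so among these four compounds the two groups holding a further nitrogen share the high region, and none of the four goes against this. No measurement at hand accounts for this.

The compounds shown do not separate the further nitrogen from the open chain. A plain hexyl chain on the amine nitrogen, or a cyclohexyl ring carrying a dimethylamino group, would tell these two apart.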